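The compounds below may be only part of what the source reports. "The series", "measured", "known", "first", "only" and "open" are said of these compounds alone.

Within the data shown here, in a toxicity assay on MT2 cells (Homo sapiens) for cytotoxicity (a lower number here means that less compound is tolerated, a higher number that more compound is tolerated), compound 2 `Cc1cccc(Cl)c1CN1CCc2cc(-c3c(C)nc(C)c([C@H](OC(C)(C)C)C(=O)O)c3N3CCC(C)(C)CC3)ccc2C1` gives 22500 nM, the only exact number measured so far. Compound 1 `Cc1nc(C)c([C@H](OC(C)(C)C)C(=O)O)c(N2CCC(C)(C)CC2)c1-c1cnc(OCCc2ccc(F)cc2)nc1` gives >= 22000 nM, which is a limit of the assay and not an exact number. Compound 3 `Cc1nc(C)c([C@H](OC(C)(C)C)C(=O)O)c(N2CCC(C)(C)CC2)c1-c1ccc2c(c1)CCN(c1ncnc3c1cnn3C)C2` has not yet been measured. It differs from compound 2 in one group, on an amine nitrogen in a ring: a group of 10 heavy atoms (6 carbon, 4 nitrogen; one five-membered aromatic ring with 2 hetero atoms, one six-membered aromatic ring with 2 hetero atoms) in place of a group of 9 heavy atoms (8 carbon, 1 chlorine; one six-membered aromatic ring of carbon only), on an amine nitrogen in a ring. Among the measured compounds shown here, no measured step shows what this swap does, so the expectation rests on little. Compound 1 and compound 2 carry different groups on the shared core, and compound 2 still gives 22500 nM, a high number on this scale. No change beyond the usual scatter is therefore expected in either direction. The expected shift is a 1.1-fold lower number from compound 2 to compound 3 (0.05 log units; within the scatter). Compound 3 is estimated to give 20000 nM, with an expected range of 9000 nM to 45000 nM.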

Compound 3, half-maximal cytotoxic concentration: >= 17000 nM
Compound 3 gave a limit, no number; the forecaster's own chance of this, stated with the estimate: 40%; the middle value is on the limit's open side.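

Compound 3 gives >= 17000 nM in this assay, which is a limit of the assay and not an exact number. The step from compound 2 to compound 3 therefore cannot be read. The compounds shown leave open whether replacing the 2-chloro-6-methylbenzyl group on an amine nitrogen in a ring changes the result in this assay at all.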